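The compounds below may be only part of what the source reports. "The series", "measured", "known", "first", "only" and "open" are said of these compounds alone.

Among the measured compounds shown here, compound 1 `CCCCCCCCNc1nc(SCc2ccc(C(F)(F)F)cc2)nc2ccccc12` is the only compound with a full number in a functional assay on MDA-MB-231 cells (Homo sapiens) for cytotoxicity, read by MTT assay, with a stated time of 72 h; on this read-out higher numbers stand for weaker inhibition and lower numbers for stronger inhibition: compound 1 gives 22300 nM. Compound 2 `Cc1ccc(Nc2nc(SCc3ccc(C(F)(F)F)cc3)nc3ccccc23)cc1` carries a 4-methylphenyl in place of octyl on a nitrogen on an aromatic ring. In this assay compound 2 reaches only > 50000 nM, which is a limit of the assay rather than a number. That gives an at least 2.2-fold higher number from compound 1 to compound 2 (0.35 log units; beyond the scatter), a shift toward weaker inhibition. Compound 3 `Fc1ccc(Nc2nc(SCc3ccc(C(F)(F)F)cc3)nc3ccccc23)cc1Cl` differs from compound 1 by 3-chloro-4-fluorophenyl in place of octyl on a nitrogen on an aromatic ring. The measured step from compound 1 to compound 2 is the one that bears on this change: both swap the octyl chain for an aromatic ring on that nitrogen, and it ran toward weaker inhibition. A step of similar size in the same direction is expected, and the result may again end at the limit of > 50000 nM in this assay, at which 1 of the 2 values shown sits. Compound 3 is therefore expected to give 50000 nM, within 20000 nM to 150000 nM, meaning an estimated 2.2-fold higher number from compound 1 to compound 3 (0.35 log units; beyond the scatter).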

Compound 3, half-maximal inhibitory concentration: 14500 nM
Compound 3: middle estimate off by 3.4-fold (0.54 log units), on the high side; measured number below the stated range.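

An aromatic ring on this nitrogen does not by itself bring weaker inhibition: in this assay, 3-chloro-4-fluorophenyl in place of octyl gives a 1.5-fold lower number from compound 1 to compound 3 (0.19 log units; within the scatter), so this ring and the octyl chain cannot be told apart here. What the ring carries makes a difference, as 3-chloro-4-fluorophenyl in place of 4-methylphenyl gives an at least 3.4-fold lower number from compound 2 to compound 3 (0.53 log units; beyond the scatter). That step starts from a limit of compound 2 and not from a number, and its full size stays unknown: the limit of > 50000 nM in this assay, at which 1 of the 3 values shown sits.

The compounds shown do not tell whether the chloro group, the fluoro group, the pair of them or the loss of the methyl group accounts for this gap. They also leave open how a plain phenyl ring, a shorter alkyl chain or a chain ending in a dimethylamino group on this nitrogen would compare.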